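This account rests on a few compounds, and the source may have more. Where it says the series, first, only, none or still open, it means among the compounds named here.

Working notes on the selenium series. Growth inhibition read in an ADME assay on MCF-10A cells (Homo sapiens) for cytotoxicity, read by MTT assay, with a stated time of 72 h; a lower number here means a stronger inhibitor of growth, a higher number a weaker inhibitor of growth:

compound 1 `O=C(/N=C(/NC(=O)c1csc([N+](=O)[O-])c1)[Se]Cc1ccccc1)c1csc([N+](=O)[O-])c1`: 54100 nM
compound 2 `C[Se]/C(=N\C(=O)c1cnc2ccccc2c1)NC(=O)c1cnc2ccccc2c1`: 52100 nM
compound 3 `O=C(/N=C(/NC(=O)c1cnc2ccccc2c1)[Se]Cc1ccccc1)c1cnc2ccccc2c1`: > 100000 nM, which is a limit of the assay and not a number

Compounds 2 and 3 share one core, compounds 1 and 4 another; the difference between the two cores is not broken down here. Compound 1 and compound 2 give numbers within the scatter of each other, so no order between them is read.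

Within the data shown here, the only step measured within a core is hydrogen in place of phenyl on a saturated chain carbon bound to a selenium atom, which gave an at least 1.9-fold lower number from compound 3 to compound 2 (0.28 log units; that floor lies within the scatter). The reading for compound 3 sits at the limit of > 100000 nM in this assay, at which 1 of the 3 values shown sits, so the size of that step is known only as a floor.

Compound 4 `C[Se]/C(=N\C(=O)c1csc([N+](=O)[O-])c1)NC(=O)c1csc([N+](=O)[O-])c1` is still to be measured in this assay. It arises from compound 1 by the same change, (hydrogen in place of phenyl on a saturated chain carbon bound to a selenium atom). Among the measured compounds shown here, the one precedent points to a lower number after this change, though only as a floor that itself lies within the scatter, and the starting point here is already a number rather than a limit. For compound 4 the expected value is 38000 nM. The step expected is a 1.4-fold lower number from compound 1 to compound 4 (0.15 log units; within the scatter), resting on the precedent an at least 1.9-fold lower number from compound 3 to compound 2 (0.28 log units; that floor lies within the scatter). The range expected for compound 4 runs from 18000 nM to 90000 nM.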

Compound 4, concentration for total growth inhibition: 4740 nM
For compound 4 the middle estimate is 8.0-fold (0.90 log units) above the measured one, and the stated range ends above it.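

On the core of compound 1, the change of benzyl to methyl, with hydrogen in place of phenyl on a saturated chain carbon bound to a selenium atom, gives in this assay a large step: an 11-fold lower number from compound 1 to compound 4 (1.06 log units; beyond the scatter). This is the first reading of the change beyond the scatter in the series, but the two steps together do not establish that its size carries from one core to the other: the same change on two cores in this assay, an at least 1.9-fold lower number (0.28 log units; that floor lies within the scatter) from compound 3 to compound 2 and an 11-fold lower number (1.06 log units; beyond the scatter) from compound 1 to compound 4; the limit leaves it open whether they differ
Compound 3 gives > 100000 nM, which is a limit of the assay and not a number.

Only benzyl and methyl are shown at this place, so it remains open how an ethyl group, a longer chain, or a chain ending in an amine or a carboxylic acid would read on either core. With only two cores shown, the size of the step on any further core also remains open, as does whether the step on the core of compound 3 would match the one on the core of compound 1 if compound 3 had a number in place of its limit.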